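The source may report more compounds than this note shows. Statements on the series, on what has been measured and on what is new or still open speak of the compounds shown alone.

Compound 1 `CC[C@H]1OC(=O)[C@H](C)C(=O)[C@H](C)[C@@H](O[C@@H]2O[C@H](C)C[C@H](N(C)Cc3ccccc3-c3cn(CCCCCC(=O)NO)nn3)[C@H]2O)[C@@](C)(OC)C[C@@H](C)C2=NCCN3C(=O)O[C@@]1(C)[C@H]3[C@H]2C`: 1190 nM
Compound 2 `CC[C@H]1OC(=O)[C@H](C)C(=O)[C@H](C)[C@@H](O[C@@H]2O[C@H](C)C[C@H](N(C)Cc3ccc(-c4cn(CC(=O)NO)nn4)cc3)[C@H]2O)[C@@](C)(OC)C[C@@H](C)C2=NCCN3C(=O)O[C@@]1(C)[C@H]3[C@H]2C`: 2850 nM

Both were measured in an assay for inhibition of histone deacetylase 8 (Homo sapiens), read by mass spectrometry, with a stated time of 60 min; on this read-out lower numbers stand for stronger inhibition and higher numbers for weaker inhibition. Compound 2 stands at the higher of the two numbers, and compound 1 sits lower by a margin beyond the usual scatter. Compound 3 `CC[C@H]1OC(=O)[C@H](C)C(=O)[C@H](C)[C@@H](O[C@@H]2O[C@H](C)C[C@H](N(C)Cc3ccc(-c4cn(CCC(=O)NO)nn4)cc3)[C@H]2O)[C@@](C)(OC)C[C@@H](C)C2=NCCN3C(=O)O[C@@]1(C)[C@H]3[C@H]2C` differs from compound 2 in one place: (hydroxycarbamoyl)methyl in place of hydroxycarbamoyl on a saturated chain carbon bound to an aromatic nitrogen. For the measured compounds named here, no single-change step between measured compounds is available, so the size of this move is uncertain; a modest shift toward a lower number is expected, a 1.8-fold lower number from compound 2 to compound 3 (0.25 log units; within the scatter). Compound 3 is estimated at 1600 nM, with a range from 600 nM to 4500 nM.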

Compound 3, half-maximal inhibitory concentration: > 10000 nM
Compound 3: a limit, no number; the forecaster's own chance of this, stated with the estimate: 5%; middle value at least 6.2-fold (0.79 log units) away from the limit.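

In this assay compound 3 gives > 10000 nM, which is a limit of the assay and not a number. Going from (hydroxycarbamoyl)methyl to 2-(hydroxycarbamoyl)ethyl gives an at least 3.5-fold higher number from compound 2 to compound 3 (0.54 log units; beyond the scatter), so inhibition at this place weakens with this small change in chain length. How far it weakens stays unknown because compound 3 sits at a limit: the limit of > 10000 nM in this assay, at which 1 of the 3 values shown sits.

Left open is how a carboxylic acid at the end of this chain would read in this assay. Compound 1 differs from compound 2 in more than one place, so it cannot show how chain length alone acts.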